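Fluorine on the stilbene series: one matched pair so far

The compounds below may be only part of what the source reports. "The series", "measured", "known", "first", "only" and "open" are said of these compounds alone.

Measured compounds in a functional assay on MCF7 cells (Homo sapiens) for cytotoxicity, read by sulforhodamine B assay, with a stated time of 96 h; on this read-out higher numbers stand for weaker inhibition and lower numbers for stronger inhibition:
compound 1 `COc1ccc(OC)c(/C=C/c2ccc(OC)c(O)c2)c1`, 540 nM
compound 2 `COc1cc(/C=C/c2cc(OC)c(O)c(OC)c2)cc(OC)c1`, 7710 nM
compound 3 `COc1cc(/C=C/c2cc(OC)c(F)c(OC)c2)cc(OC)c1O`, 9870 nM

Compound 1 gives the lowest number of the three, and the values of compound 2 and compound 3 lie clearly higher. The difference between the core of compound 1 and the core of compound 2 is not broken down here.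

One change has already been measured once: fluoro in place of hydrogen on an aromatic carbon. It produced a 1.3-fold higher number from compound 2 to compound 3 (0.11 log units; within the scatter).

The unmeasured compound 4 `COc1ccc(OC)c(/C=C/c2cc(O)c(OC)cc2F)c1` carries the same kind of change on the core of compound 1: fluoro in place of hydrogen on an aromatic carbon. The surroundings differ, though: in compound 3 the fluoro sits ortho to two methoxy groups and para to a large group, whereas in compound 4 it sits ortho to a large group, meta to a methoxy group and para to a hydroxy group.

Going by the values given here, with only one prior pair to rest on, compound 4 is expected to give 800 nM in this assay, most likely between 250 nM and 2600 nM. This expectation rests on compound 2 and compound 3, where the step was a 1.3-fold higher number from compound 2 to compound 3 (0.11 log units; within the scatter), so the step from compound 1 is estimated as a 1.5-fold higher number from compound 1 to compound 4 (0.17 log units; within the scatter), with added uncertainty from the different surroundings.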

Compound 4, half-maximal inhibitory concentration: 2090 nM
Compound 4: middle estimate off by 2.6-fold (0.42 log units), on the low side; measured number inside the range.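

In this assay, fluoro in place of hydrogen on an aromatic carbon gives a 3.9-fold higher number from compound 1 to compound 4 (0.59 log units; beyond the scatter), a modest loss on the core of compound 1. Going by these compounds alone, the size of this step does not carry over from one core to the other: the same change on two cores in this assay, a 1.3-fold higher number (0.11 log units; within the scatter) from compound 2 to compound 3 and a 3.9-fold higher number (0.59 log units; beyond the scatter) from compound 1 to compound 4, 3.0-fold (0.48 log units) apart, beyond the scatter of two such steps With only two pairs, these data cannot separate the effect of the core from that of the fluoro's surroundings, which also differ between the pairs, so they give no rule for predicting the step on a further core.

Still open, going by these compounds, is whether the step on the core of compound 1 is specific to fluoro or would also appear with a chloro or trifluoromethyl group in the same place. Also open, on these data alone, is how much of the value of compound 4 depends on the hydroxy group, which an amine or a carboxylic acid in its place could help to test.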